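A few compounds are considered here, and "the series" means these few. Any claim that something is new, unique, unknown or untested is made for them only; others in the source may bear on it.

Measured so far:
compound 1, `CC1CC(=O)N(CC(=O)N2CCN(c3ccccc3)CC2)C1=O`: 300 mg/kg
compound 2, `Cc1cccc(N2CCN(C(=O)CN3C(=O)CC(C)C3=O)CC2)c1`: 300 mg/kg

In a functional assay on the whole organism (strain CD1) with Mus musculus as the target, in the maximal electroshock model, with a stated time of 0.5 h (on this read-out lower numbers stand for an effect already at smaller amounts and higher numbers for an effect only at larger amounts of compound), compound 1 gives 300 mg/kg. Within the data shown here, compound 2 gives 300 mg/kg in this assay, and the single recorded step, no change at the digits printed from compound 1 to compound 2 (within the scatter), leaves compound 2 level with compound 1 on the numbers at hand; there is no order between them.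

Compound 3, `CC1CC(=O)N(CC(=O)N2CCN(c3ccc(Cl)c(Cl)c3)CC2)C1=O`, has not yet been run in this assay. It differs from compound 2 in one place: 3,4-dichlorophenyl in place of 3-methylphenyl on an amine nitrogen in a ring. Among the measured compounds shown here, the only measured step that bears on this position is the one on the same aromatic ring carried by the amine nitrogen in the ring, no change at the digits printed from compound 1 to compound 2 (within the scatter), which was flat. For the measured compounds named here, no measured compound carries chlorine on this ring, and none carries two substituents on it, so the data give no direction for the larger exchange. The step from compound 2 to compound 3 is therefore expected to be no change at the digits printed from compound 2 to compound 3 (within the scatter), none beyond the scatter. Compound 3 is estimated at 300 mg/kg in this assay, with a range from 100 mg/kg to 600 mg/kg.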

Compound 3, minimum effective dose: 300 mg/kg
Estimate against measurement, compound 3: no gap at the digits printed; the range from low to high includes it.
By their numbers in this assay, from the lowest: compounds 1, 2 and 3 (each within the scatter of the next).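

In this assay, the aryl group on the amine nitrogen in the ring now takes a much larger exchange than the single methyl of the earlier pair, and 3,4-dichlorophenyl in place of 3-methylphenyl gives no change at the digits printed from compound 2 to compound 3 (within the scatter). Against the unsubstituted phenyl, the same group gives no change at the digits printed from compound 1 to compound 3 (within the scatter), so chlorine on this aromatic ring and two substituents on it both leave the printed value where it stood, and compound 1, compound 2 and compound 3 stand level with no order among them. Nothing on hand accounts for this flat result.

From the compounds shown here alone, it remains open whether any group on this aromatic ring moves the minimum effective dose away from this level, for instance a methoxy group, a nitrile or a carboxylic acid, or a pyridine ring in place of the phenyl. The compounds shown differ only in this aryl group, so it is also open how the read-out responds to changes elsewhere, such as a longer chain between the core's two amide carbonyl groups or an ethyl group in place of the methyl on the core.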